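A few compounds are considered here, and "the series" means these few. Any claim that something is new, unique, unknown or untested is made for them only; others in the source may bear on it.

For the measured compounds named here, in a functional assay on HeLa cells (Homo sapiens) for antiproliferative activity, read by MTT assay, with a stated time of 72 h (on this read-out higher numbers stand for weaker inhibition and lower numbers for stronger inhibition), compound 2 `C/C=C/C(=O)Nc1cccc(Oc2nc(Nc3cccc(C#N)c3)nc3c2CSCC3)c1` gives 12800 nM, the only actual number so far. Going by the values given here, the only other measured compound, compound 1 `C/C=C/C(=O)Nc1cccc(Oc2nc(Nc3ccn(C)n3)nc3c2CSCC3)c1`, is reported just as a limit, > 50000 nM. Among the compounds with values here, the single measured step, an at least 3.9-fold lower number from compound 1 to compound 2 (0.59 log units; beyond the scatter), came with 3-cyanophenyl in place of 1-methyl-1H-pyrazol-3-yl on a nitrogen on an aromatic ring.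

Compound 3 `CC(C)=CC(=O)Nc1cccc(Oc2nc(Nc3cccc(C#N)c3)nc3c2CSCC3)c1` keeps the 3-cyanophenyl and differs at another place, with 2-methylprop-1-en-1-yl in place of prop-1-en-1-yl on a carbonyl carbon. Within the data shown here, no measured step touches the group on the carbonyl carbon, so the one step available gives no direct size for this change. The starting point for the expectation is therefore simply the value of compound 2, 12800 nM.

The step expected in this assay is a 1.4-fold higher number from compound 2 to compound 3 (0.15 log units; within the scatter), which is expected to stay small, leaning only slightly towards weaker inhibition. Compound 3 is estimated at 18000 nM, with an expected range from 7000 nM to 50000 nM.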

Compound 3, half-maximal inhibitory concentration: 29200 nM
For compound 3 the middle estimate is 1.6-fold (0.21 log units) below the measured one; the measured number falls inside the stated range.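

Changing the group on the carbonyl carbon gave a 2.3-fold higher number from compound 2 to compound 3 (0.36 log units; beyond the scatter) in this assay, so the swap of prop-1-en-1-yl for 2-methylprop-1-en-1-yl shifts the read-out towards weaker inhibition by more than the scatter. For the compounds shown here, until now the only step lay at the group on the nitrogen, so this is the first sign that a second place also affects the read-out, and this step has an exact size, with actual numbers at both ends. Compound 1 remains the only compound reported as a limit, which leaves the earlier step as a bound and means its size cannot be ranked exactly against the new one: the limit of > 50000 nM in this assay, at which 1 of the 3 values shown sits.

Going by these compounds, it remains open whether a plain ethenyl group, a saturated propyl chain or a chain carrying a dimethylamino group on the same carbonyl carbon would give a lower or a higher number than compound 2. On these data alone, it is also open whether the 2-methylprop-1-en-1-yl group would have a step of similar size with 1-methyl-1H-pyrazol-3-yl in place of 3-cyanophenyl on the nitrogen.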